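Compound 4 and the limit of the series

The compounds below may be only part of what the source reports. "The series", "measured", "known", "first", "only" and "open" are said of these compounds alone.

compound 1 `CC1(/C=C/c2ccccc2)C=CC(=O)O1`: > 1000000 nM
compound 2 `CC1(/C=C/c2ccc(F)cc2)C=CC(=O)O1`: > 1000000 nM
compound 3 `CC1(/C=C/c2ccccc2O)C=CC(=O)O1`: > 1000000 nM

In a functional assay on K562 cells (Homo sapiens) for inhibition, read by sulforhodamine B assay, with a stated time of 48 h (a higher number here means a weaker inhibitor of growth, a lower number a stronger inhibitor of growth), all three entries are limits and not numbers. Compound 1 stands at > 1000000 nM and this is a limit, so the starting point of the step has no readable value. Among the compounds with values here, the series so far is summed up by the limit of > 1000000 nM in this assay, at which 3 of the 3 values shown sit, and no compound has yet given a number.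

Compound 4 `CC1(/C=C/c2cccc(O)c2)C=CC(=O)O1` differs from compound 1 by hydroxy in place of hydrogen on an aromatic carbon with the hydroxy meta to a group of 9 heavy atoms.

The closest measured change is a step that the two limits leave unreadable from compound 1 to compound 3 which is also hydroxy in place of hydrogen on an aromatic carbon. The other measured change is a step that the two limits leave unreadable from compound 1 to compound 2 with fluoro in place of hydrogen on an aromatic carbon. Neither has a size that can be carried over, and neither gives a direction. On this basis no step beyond the scatter is expected in this assay and a report of compound 4 as a limit again is the likeliest outcome.

The expected outcome is a number no higher from compound 1 to compound 4 (the limit leaves the size open) as an estimate only. Compound 4 is estimated at 1000000 nM with an expected range from 300000 nM to 3000000 nM in this estimate.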

Compound 4, concentration for total growth inhibition: > 1000000 nM
Compound 4: only a limit was reported; the forecaster's own chance of this, stated with the estimate: 85%; the middle value lies on the limit itself.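

No new step can be read between compound 1 and compound 4 in this assay, since both are reported only as limits: the limit of > 1000000 nM in this assay, at which 4 of the 4 values shown sit.

The compounds shown leave open whether hydroxy or fluoro in place of hydrogen on an aromatic carbon changes growth inhibition at all, and in which direction.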